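One Trifluoromethyl Removed From a Urea Tail

The compounds below may be only part of what the source reports. "The series", "measured", "known", "first", "only" and "open" are said of these compounds alone.

Compound 1 `O=C(Nc1cccc(-n2cc(-c3ccncc3)c(-c3ccc(Cl)c(O)c3)n2)c1)Nc1cc(C(F)(F)F)cc(C(F)(F)F)c1` gives 1010 nM in a functional assay on CAKI-1 cells (Homo sapiens) for inhibition, read by sulforhodamine B assay, with a stated time of 48 h; a lower number here means a stronger inhibitor of growth, a higher number a weaker inhibitor of growth; compound 2 `COc1cc(-c2nn(-c3cccc(NC(=O)Nc4ccc(Cl)c(C(F)(F)F)c4)c3)cc2-c2ccncc2)ccc1Cl` gives 992 nM in the same assay, and the two numbers lie within the scatter of each other. Compound 3 `O=C(Nc1cccc(-n2cc(-c3ccncc3)c(-c3ccc(Cl)c(O)c3)n2)c1)Nc1cccc(C(F)(F)F)c1` has not been measured. It differs from compound 1 in one place: hydrogen in place of trifluoromethyl on an aromatic carbon. For the measured compounds named here, no measured pair shows what such a change does here, so the step from compound 1 to compound 3 is expected to be small, at most a modest weakening, estimated as a 1.5-fold higher number from compound 1 to compound 3 (0.17 log units; within the scatter). Compound 3 is expected to give about 1500 nM, between 600 nM and 4000 nM.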

Compound 3, concentration for 50% growth inhibition: 1750 nM
Compound 3: the middle estimate sits 1.2-fold (0.07 log units) below what was measured; the range from low to high includes it.
By their numbers in this assay, from the lowest: compounds 2, 1 and 3 (each within the scatter of the next).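

Hydrogen in place of trifluoromethyl on this aromatic carbon gives a 1.7-fold higher number from compound 1 to compound 3 (0.24 log units; within the scatter) in this assay. This first one-place comparison therefore shows that compound 1 and compound 3 cannot be told apart in this assay, even though four heavy atoms leave the ring. No measurement here offers an explanation for this result.

Going by these compounds, whether an amine or a carboxylic acid on the same carbon would give a step beyond the scatter remains open. So does whether the same change would behave alike on other compounds.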